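A halogenated aryl urea after the inactive furan amide

This account rests on a few compounds, and the source may have more. Where it says the series, first, only, none or still open, it means among the compounds named here.

Measured so far in a functional assay on A2780 cells (Homo sapiens) for antiproliferative activity, read by fluorescence, with a stated time of 72 h; a higher number here means a weaker inhibitor, a lower number a stronger inhibitor:
Compound 1 `CN1CCC(C(=O)N2Cc3c(NC(=O)c4ccc(Cl)cc4)n[nH]c3C2(C)C)CC1`: 120 nM
Compound 2 `CN1CCC(C(=O)N2Cc3c(NC(=O)c4ccco4)n[nH]c3C2(C)C)CC1`: > 5000 nM

Compound 2 has no exact number, only a limit of the assay (> 5000 nM). Among the measured compounds shown here, the only measured step (an at least 41-fold higher number from compound 1 to compound 2 (1.61 log units; beyond the scatter)) is large and put furan-2-yl in place of 4-chlorophenyl on a carbonyl carbon. Compound 3 `CN1CCC(C(=O)N2Cc3c(NC(=O)Nc4cccc(F)c4)n[nH]c3C2(C)C)CC1` changes that same place ((3-fluorophenyl)amino in place of furan-2-yl on a carbonyl carbon), with (3-fluorophenyl)amino in place of furan-2-yl. Like compound 1 (120 nM), compound 3 carries a six-membered aromatic ring of carbon only, so a large move back towards stronger inhibition in this assay is expected. As far as these compounds go, the new amino link is untested here, so full recovery is uncertain. The expected change is an at least 16-fold lower number from compound 2 to compound 3 (1.22 log units; beyond the scatter). For compound 3 the estimated value is 300 nM (expected range 60 nM to 1800 nM).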

Compound 3, half-maximal inhibitory concentration: 350 nM
Compound 3: the middle estimate sits 1.2-fold (0.07 log units) below what was measured, and the stated range covers the measured number.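

In this assay, this place on the carbonyl carbon accepts (3-fluorophenyl)amino, an aromatic ring joined through an amino link, and activity returns after the furan-2-yl amide (an at least 14-fold lower number from compound 2 to compound 3 (1.15 log units; beyond the scatter)). Even so, compound 3 does not fully match the 4-chlorophenyl amide (a 2.9-fold higher number from compound 1 to compound 3 (0.46 log units; beyond the scatter)), so the link and the ring's halogen can change together while activity stays measurable, though at a cost beyond the scatter. The first of these steps has only a minimum size, since compound 2 stands at (> 5000 nM), which is a limit of the assay: the limit of > 5000 nM in this assay, at which 1 of the 3 values shown sits.

The compounds shown cannot say whether the amino link or the change of halogen accounts for the gap to compound 1. A 3-fluorophenyl group joined directly to the carbonyl, or a (4-chlorophenyl)amino group, would separate those two changes.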